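Swapping the ester side chain for an alcohol

A few compounds are considered here, and "the series" means these few. Any claim that something is new, unique, unknown or untested is made for them only; others in the source may bear on it.

Compound 1 `COC(=O)/C=C\[C@H]1OCCC[C@H]1O[Si](C)(C)C(C)(C)C` gives 7300 nM
Compound 2 `COC(=O)/C=C/[C@H]1OCCC[C@H]1O[Si](C)(C)C(C)(C)C` gives 98000 nM

In a functional assay on A2780 cells (Homo sapiens) for inhibition, read by sulforhodamine B assay (a higher number here means a weaker inhibitor of growth, a lower number a stronger inhibitor of growth), compound 2 gives 98000 nM and holds the higher of the two numbers, which makes it the weaker growth inhibitor of the pair. Compound 3 `CC(C)(C)[Si](C)(C)O[C@@H]1CCCO[C@@H]1/C=C\CO` keeps the shared core but carries 3-hydroxyprop-1-en-1-yl in place of 2-(methoxycarbonyl)ethenyl on a saturated ring carbon. Its double bond is drawn Z, as in compound 1. Within the data shown here, one measured step bears on this: the large change of a 13-fold higher number from compound 1 to compound 2 (1.13 log units; beyond the scatter) goes with the fact that compounds 1 and 2 differ only in the configuration as drawn and lies beyond the scatter. Among the measured compounds shown here, no measured step tests the new group, so only part of that gain is expected to return. The expected change is a 4.9-fold lower number from compound 2 to compound 3 (0.69 log units; beyond the scatter) in this assay and points to stronger inhibition. Compound 3 is estimated at 20000 nM with an expected range (from 6000 nM to 70000 nM).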

Compound 3, concentration for 50% growth inhibition: > 100000 nM
Compound 3 ended at the assay's limit (the forecaster's own chance of this, stated with the estimate: 15%); middle value at least 5.0-fold (0.69 log units) from the limit.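

In this assay compound 3 gives > 100000 nM, which is a limit of the assay and not a number. With the double bond drawn Z in both compounds, putting hydroxymethyl in place of methoxycarbonyl gives an at least 13-fold higher number from compound 1 to compound 3 (1.13 log units; beyond the scatter), so at this position the Z double bond alone does not keep the growth inhibition seen with compound 1. The other step, an at least 1.0-fold higher number from compound 2 to compound 3 (0.00 log units; that floor lies within the scatter), gives no order for that pair because the reading stops at the end of the scale: the limit of > 100000 nM in this assay, at which 1 of the 3 values shown sits.

The compounds shown leave open whether a carboxylic acid or an amide in place of the methoxycarbonyl would keep the inhibition of compound 1. They also leave open how the alcohol side chain reads with its double bond drawn E.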